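The source may hold more compounds than are shown below. What is called first, only, known or untested is meant among the compounds shown, and "the series" means these compounds.

Compound 1, with the structure `CCCCc1nc(=O)c(S(=O)(=O)c2ccc(-n3ccccc3=O)cc2)c(O)n1-c1c(OC)cccc1OC`, is the starting point of this small series. In an ADME assay on microsomes from liver (Rattus norvegicus) for metabolic stability, using NADPH, with a stated time of 10 min (on this read-out lower numbers stand for a less stable compound and higher numbers for a more stable compound), compound 1 gives 83%. Compound 2, with the structure `CCCCc1nc(=O)c(S(=O)(=O)c2ccc(-n3cc(Cl)ccc3=O)cc2)c(O)n1-c1c(OC)cccc1OC`, differs from compound 1 only in one place, namely (chloro in place of hydrogen on an aromatic carbon), and in this assay compound 2 gives 74%. The step that this change made is a number 9 percentage points lower from compound 1 to compound 2 (within the scatter), so the two values cannot be told apart within the usual scatter of the read-out.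

Compound 3, with the structure `CCCCc1[nH]c(=O)c(S(=O)(=O)c2ccc(-n3ccccc3=O)cc2)c(O)c1-c1c(OC)cccc1OC`, carries a different core; how its core differs from that of compound 1 is not broken down here. In this assay compound 3 gives 100%, the highest of the three values, and its distance from compound 1 and from compound 2 lies beyond the scatter in both cases.

Compound 4, with the structure `CCCCc1[nH]c(=O)c(S(=O)(=O)c2ccc(-n3cc(Cl)ccc3=O)cc2)c(O)c1-c1c(OC)cccc1OC`, has not yet been measured. It stands to compound 3 as compound 2 stands to compound 1: the change is chloro in place of hydrogen on an aromatic carbon, the same change made on the other core. For the step in this assay the account expects a number 7 percentage points lower from compound 3 to compound 4 (within the scatter), resting on the measured step of a number 9 percentage points lower from compound 1 to compound 2 (within the scatter), which stayed within the scatter. Compound 4 is therefore estimated to give 93% in this assay, with the range 78% to 100%.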

Compound 4, percent of the compound remaining: 72%
Compound 4: middle estimate off by 21 percentage points, on the high side; measured number below the stated range.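

In this assay, the change of hydrogen to chloro on an aromatic carbon does not carry over from one core to the other at the same size: the same change on two cores in this assay, a number 9 percentage points lower (within the scatter) from compound 1 to compound 2 and a number 28 percentage points lower (beyond the scatter) from compound 3 to compound 4, 19 percentage points apart, beyond the scatter of two such steps. On the core of compound 3 the change gives a number 28 percentage points lower from compound 3 to compound 4 (beyond the scatter), so the small step seen on the core of compound 1 was no safe guide to the step on the other core in this series. This shows that the effect of this change on the read-out depends on the core in this one pair of pairs, but it does not show which part of the core is responsible, why the two steps differ, or whether the same would hold for a chloro placed elsewhere or for any other read-out.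

The compounds shown leave open whether a fluoro, a methyl or a nitrile on the same aromatic carbon would track the chloro on each core, or whether the larger step on the core of compound 3 is specific to chlorine. They also leave open whether the two cores would part in the same way for a change elsewhere in the structure, such as a longer chain in place of the butyl chain or an amine on the ring that carries the sulfonyl group.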